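Replacing pyridin-2-yl with 1H-pyrazol-5-yl in compound 3

The compounds below may be only part of what the source reports. "The series", "measured", "known", "first", "only" and "open" are said of these compounds alone.

Compound 1 `CCCCc1nc(C(C)(C)C)nc2nc(N)c(C#N)c(N)c12`: 6000 nM
Compound 2 `CC(C)(C)c1nc(-c2nccs2)c2c(N)c(C#N)c(N)nc2n1`: < 1500 nM
Compound 3 `CC(C)(C)c1nc(-c2ccccn2)c2c(N)c(C#N)c(N)nc2n1`: 87000 nM

All three values come from a physicochemical assay for solubility, in phosphate buffer, with a stated time of 18 h; on this read-out lower numbers stand for lower solubility and higher numbers for higher solubility. The entry for compound 2, < 1500 nM, is a limit of the assay and not a number. Among the values shown, compound 3 stands highest at 87000 nM. The nearest number lies well under it: a 15-fold higher number from compound 1 to compound 3 (1.16 log units; beyond the scatter).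

The next compound is compound 4 `CC(C)(C)c1nc(-c2ccn[nH]2)c2c(N)c(C#N)c(N)nc2n1`, with 1H-pyrazol-5-yl in place of pyridin-2-yl on an aromatic carbon.

The closest measured exchange at this place is an at least 58-fold higher number from compound 2 to compound 3 (1.76 log units; beyond the scatter). Read in reverse, it links a six-membered aromatic ring to a lower result with a five-membered one. The two steps from the butyl compound, an at least 4.0-fold lower number from compound 1 to compound 2 (0.60 log units; beyond the scatter) and a 15-fold higher number from compound 1 to compound 3 (1.16 log units; beyond the scatter), show that the group at this place can move the result either way. Going by the values given here, no measured compound carries 1H-pyrazol-5-yl, so the guide is loose, and the full size of the step to compound 2 is not assumed. A large fall in this assay is expected, resting on compound 2 and an at least 58-fold higher number from compound 2 to compound 3 (1.76 log units; beyond the scatter). The expected change is a 5.8-fold lower number from compound 3 to compound 4 (0.76 log units; beyond the scatter). For compound 4 the estimate is 15000 nM, with an expected range of 2500 nM to 80000 nM.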

Compound 4, solubility: 13500 nM
Beside the measured number, compound 4's estimate is 1.1-fold (0.05 log units) above it, and the stated range covers the measured number.
By their numbers in this assay, from the lowest: compound 1; then compound 4; then compound 3. At a limit, below all of these: compound 2.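

In this assay, the exchange of pyridin-2-yl for 1H-pyrazol-5-yl gives a 6.4-fold lower number from compound 3 to compound 4 (0.81 log units; beyond the scatter), so among the three aromatic rings at this place, both five-membered rings stand under the six-membered one. The two five-membered rings do not read alike, however: the step between them is an at least 9.0-fold higher number from compound 2 to compound 4 (0.95 log units; beyond the scatter), and against butyl the 1H-pyrazol-5-yl group gives a 2.3-fold higher number from compound 1 to compound 4 (0.35 log units; beyond the scatter), so a five-membered ring can stand above butyl here, which compound 2 goes against. The entry for compound 2 is a limit and not a number: the limit of < 1500 nM in this assay, at which 1 of the 4 values shown sits.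

Each exchange among the aromatic rings changes several counted features at once, such as ring size, hetero atoms or hydrogen-bond donors, and the compounds shown do not separate them. On these data alone, how an amine, a carboxylic acid or a chain longer than butyl on this aromatic carbon would read in this assay stays open, as does whether a six-membered ring other than pyridin-2-yl would stay above the five-membered ones.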